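Replacing the amide side chain of compound 3

The compounds below may be only part of what the source reports. "The series", "measured", "known", "first", "only" and "open" are said of these compounds alone.

Measured in a functional assay on HepG2 cells (Homo sapiens), read by MTT assay, with a stated time of 48 h; on this read-out lower numbers stand for stronger inhibition and higher numbers for weaker inhibition:
- Compound 1 `CCN(CC)CCNC(=O)c1ccc(C(CC)(CC)c2ccc(OCC(=O)C(C)(C)C)c(C)c2)n1CC`: 620 nM
- Compound 2 `CCN(CC)CCCNC(=O)c1ccc(C(CC)(CC)c2ccc(OCC(=O)C(C)(C)C)c(C)c2)n1CC`: 180 nM
- Compound 3 `CCn1c(C(=O)NCCN)ccc1C(CC)(CC)c1ccc(OCC(=O)C(C)(C)C)c(C)c1`: 180 nM

Compound 3 stands level with compound 2, and together they hold the lowest number of this small set. Compound 1, at 620 nM, holds the highest.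

The next compound is compound 4 `CCn1c(C(=O)N(C)CC(=O)O)ccc1C(CC)(CC)c1ccc(OCC(=O)C(C)(C)C)c(C)c1`. It keeps the shared core and puts (carboxymethyl)(methyl)amino in place of (2-aminoethyl)amino on a carbonyl carbon.

Going by the values given here, three measured steps bear on this part of the molecule. The number falls modestly in a 3.4-fold lower number from compound 1 to compound 2 (0.54 log units; beyond the scatter), and by the same amount in a 3.4-fold lower number from compound 1 to compound 3 (0.54 log units; beyond the scatter). Within the scatter, no change at the digits printed from compound 2 to compound 3 (within the scatter). Changes here have so far moved this assay only modestly. However, all three compounds carry an amino group on the chain and none carries carboxymethyl, so these steps are only a rough guide to size and say little about direction.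

A modest step towards a higher number, meaning weaker inhibition, is therefore expected, though with wide uncertainty. The expected change is a 4.4-fold higher number from compound 3 to compound 4 (0.65 log units; beyond the scatter). Compound 4 is estimated at 800 nM, with an expected range of 200 nM to 3500 nM.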

Compound 4, half-maximal inhibitory concentration: 25200 nM
The estimate for compound 4 lay 32-fold (1.50 log units) below the measured number, outside the stated range (above it).
By their numbers in this assay, from the lowest: compounds 2 and 3 (each within the scatter of the next); then compound 1; then compound 4.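

In this assay, putting (carboxymethyl)(methyl)amino on this carbonyl carbon gives a 140-fold higher number from compound 3 to compound 4 (2.15 log units; beyond the scatter) and a 140-fold higher number from compound 2 to compound 4 (2.15 log units; beyond the scatter) as well as a 41-fold higher number from compound 1 to compound 4 (1.61 log units; beyond the scatter) so the loss holds against all three earlier side chains. Those three compounds all end in an amino group and differ from one another by modest steps at most, so they showed only how far this assay moves when the amine is altered; compound 4 shows that a side chain ending in a carboxylic acid, with no amine, can cost far more inhibition at this position. No measurement shown explains why the number rises so steeply.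

This single change removes the terminal amino group, brings in the carboxylic acid and adds a methyl group on the amide nitrogen, and the compounds shown do not separate these three parts. A comparison with (carboxymethyl)amino, which lacks that methyl group, with (2-aminoethyl)(methyl)amino, which keeps the amine, or with the methyl ester of the acid would show which part carries the loss.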